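Replacing 5-(methoxymethyl)furan-2-yl with 1-benzofuran-2-yl

The compounds below may be only part of what the source reports. "The series", "measured", "known", "first", "only" and "open" are said of these compounds alone.

Compounds 1, 2 and 3 share a core and differ in one group. In a functional assay on NCI-H460 cells (Homo sapiens) for cytotoxicity, read by MTT assay, with a stated time of 72 h (on this read-out lower numbers stand for stronger inhibition and higher numbers for weaker inhibition), compound 1 `O=c1[nH]/c(=C\c2cccs2)c(=O)[nH]/c1=C\c1cccc(Oc2ccc(F)cc2)c1` gives > 1000 nM, which is a limit of the assay. Compound 2 `O=c1[nH]/c(=C\c2ccc(Br)o2)c(=O)[nH]/c1=C\c1cccc(Oc2ccc(F)cc2)c1` gives 361 nM. Compound 3 `COCc1ccc(/C=c2\[nH]c(=O)/c(=C/c3cccc(Oc4ccc(F)cc4)c3)[nH]c2=O)o1` gives 14 nM, the lowest number of the three. Compound 4 `O=c1[nH]/c(=C\c2cc3ccccc3o2)c(=O)[nH]/c1=C\c1cccc(Oc2ccc(F)cc2)c1` changes that same group: 1-benzofuran-2-yl in place of 5-(methoxymethyl)furan-2-yl on a double-bonded chain carbon bound to an aromatic carbon. Changes to this group have moved the number far: an at least 71-fold lower number from compound 1 to compound 3 (1.85 log units; beyond the scatter), and an at least 2.7-fold lower number from compound 1 to compound 2 (0.44 log units; beyond the scatter). Compound 4 loses the methoxymethyl, whose arrival in place of bromo gave a 26-fold lower number from compound 2 to compound 3 (1.41 log units; beyond the scatter), so some of that gain is expected to be lost. In this assay the expected change is a 6.4-fold higher number from compound 3 to compound 4 (0.81 log units; beyond the scatter), clearly towards weaker inhibition. For compound 4 the estimate is 90 nM, with an expected range from 15 nM to 600 nM.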

Compound 4, half-maximal inhibitory concentration: 347 nM
Estimate against measurement, compound 4: 3.9-fold (0.59 log units) below; the measured number falls inside the stated range.
By their numbers in this assay, from the lowest: compound 3; then compounds 4 and 2 (each within the scatter of the next). At a limit, above all of these: compound 1.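

Putting 1-benzofuran-2-yl in place of 5-(methoxymethyl)furan-2-yl gives up the gain (a 25-fold higher number from compound 3 to compound 4 (1.39 log units; beyond the scatter)), so an added six-membered aromatic ring does not stand in for the methoxymethyl. Compound 4 and compound 2 cannot be told apart (a 1.0-fold lower number from compound 2 to compound 4 (0.02 log units; within the scatter)), which leaves compound 3 alone at the low end. The step from thiophen-2-yl (an at least 2.8-fold lower number from compound 1 to compound 4 (0.45 log units; beyond the scatter)) is only a bound, as compound 1 stands at a limit: the limit of > 1000 nM in this assay, at which 1 of the 4 values shown sits.

On these data alone, whether the oxygen of the methoxymethyl matters stays open. A propyl chain in its place would test that, while hydroxymethyl or aminomethyl would show whether other groups can match it.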